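The source may hold more compounds than are shown below. What is called first, only, known or untested is meant among the compounds shown, and "the series" means these compounds.

The series rests on one shared core, varied only at the amide. Among the measured compounds shown here, compound 1 `CN(CCCn1ccnc1)C(=O)[C@@H]1CCCN1c1nccc(Nc2ccccc2)n1` and compound 2 `COC[C@@H]1CCCN1C(=O)[C@@H]1CCCN1c1nccc(Nc2ccccc2)n1` are the two measured members. In an assay on isolated protein for inhibition of ribosomal protein S6 kinase beta-1 (Homo sapiens), read by HTRF, tested at 10 uM (a lower number here means less inhibition, a higher number more inhibition at the concentration tested (going by the name of the read-out)), compound 1 gives 6%. In this assay compound 2 gives 8%. For the measured compounds named here, the single measured step, a number 2 percentage points higher from compound 1 to compound 2 (within the scatter), leaves compound 2 standing alongside compound 1 in this assay, the two numbers not separable from each other. Compound 3 `CN(C)CC(C)(C)CNC(=O)[C@@H]1CCCN1c1nccc(Nc2ccccc2)n1` is the next variant at the same carbonyl carbon: (2-((dimethylamino)methyl)-2-methylpropyl)amino in place of 2-(methoxymethyl)pyrrolidin-1-yl on a carbonyl carbon. Going by the values given here, the one step that bears on this exchange, a number 2 percentage points higher from compound 1 to compound 2 (within the scatter), lay within the scatter, and both amide variants measured so far sit at low inhibition in this assay, so the expected step of a number 1 percentage points lower from compound 2 to compound 3 (within the scatter) stays within the scatter, with no direction favoured. Compound 3 is therefore expected to give about 7% in this assay, with a range from -5% to 20%.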

Compound 3, a percentage reported as inhibition, at one concentration (the size of the read-out at that concentration, not a potency): 13%
Estimate against measurement, compound 3: 6 percentage points below; the range from low to high includes it.
By their numbers in this assay, from the lowest: compounds 1, 2 and 3 (each within the scatter of the next).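

At the carbonyl carbon, (2-((dimethylamino)methyl)-2-methylpropyl)amino, with no ring and a hydrogen-bond donor, in place of 2-(methoxymethyl)pyrrolidin-1-yl, with a five-membered ring and no donor, gives a number 5 percentage points higher from compound 2 to compound 3 (within the scatter) in this assay. In the same assay, exchange of (3-(1H-imidazol-1-yl)propyl)(methyl)amino for the same group gives a number 7 percentage points higher from compound 1 to compound 3 (within the scatter), so neither the loss of the ring nor the gain of the donor separates compound 3 from the earlier amides. No evidence on the origin of these small differences is available.

Still open, as far as these compounds go, is whether any group on this carbonyl carbon can lift inhibition clear of the scatter at the concentration tested. A carboxylic acid or a morpholine at the end of a longer chain would extend the range of groups at this position.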